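Replacing 2,4,6-trihydroxyphenyl with 3,5-dimethylphenyl

The compounds below may be only part of what the source reports. "The series", "measured", "known", "first", "only" and "open" are said of these compounds alone.

In a functional assay on DU-145 cells (Homo sapiens) for inhibition, read by trypan blue exclusion, with a stated time of 96 h (on this read-out lower numbers stand for stronger inhibition of growth and higher numbers for weaker inhibition of growth), compound 1 (`O=C(/C(=C\c1ccc(O)cc1O)Sc1ccc(Br)cc1)c1ccc(Cl)cc1`) gives 50000 nM, compound 2 (`Cc1ccc(C)c(/C=C(/Sc2ccc(Br)cc2)C(=O)c2ccc(Cl)cc2)c1`) gives 10000 nM and compound 3 (`O=C(/C(=C\c1c(O)cc(O)cc1O)Sc1ccc(Br)cc1)c1ccc(Cl)cc1`) gives 50000 nM. Among the measured compounds shown here, compound 3 thus stands level with compound 1, and together they hold the highest number of the series so far.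

Compound 4 (`Cc1cc(C)cc(/C=C(/Sc2ccc(Br)cc2)C(=O)c2ccc(Cl)cc2)c1`) departs from compound 3 as follows: 3,5-dimethylphenyl in place of 2,4,6-trihydroxyphenyl on a double-bonded chain carbon bound to a double-bonded chain carbon. In words, this is 3,5-dimethylphenyl in place of 2,4,6-trihydroxyphenyl on a double-bonded chain carbon bound to a double-bonded chain carbon.

Two modest steps bear on this change: a 5.0-fold lower number from compound 1 to compound 2 (0.70 log units; beyond the scatter) and a 5.0-fold higher number from compound 2 to compound 3 (0.70 log units; beyond the scatter). Both separate a hydroxylated phenyl from 2,5-dimethylphenyl, the dimethylphenyl being lower. The added hydroxy, by contrast, gives no change at the digits printed from compound 1 to compound 3 (within the scatter). For the measured compounds named here, no measured compound carries 3,5-dimethylphenyl, so the transfer from 2,5-dimethylphenyl remains an assumption.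

A modest drop is therefore expected, estimated as a 4.2-fold lower number from compound 3 to compound 4 (0.62 log units; beyond the scatter). The expected value for compound 4 is 12000 nM, with an estimated range of 4000 nM to 40000 nM.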

Compound 4, concentration for 50% growth inhibition: 10000 nM
Estimate against measurement, compound 4: 1.2-fold (0.08 log units) above; the measured number falls inside the stated range.
By their numbers in this assay, from the lowest: compounds 2 and 4 (each within the scatter of the next); then compounds 1 and 3 (each within the scatter of the next).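

In this assay, 3,5-dimethylphenyl separates from both hydroxylated groups by steps of the same size (a 5.0-fold lower number from compound 3 to compound 4 (0.70 log units; beyond the scatter) and a 5.0-fold lower number from compound 1 to compound 4 (0.70 log units; beyond the scatter)), so the lower number seen for compound 2 is now shared by a second dimethylphenyl group. The step from 2,5-dimethylphenyl shows no change at the digits printed from compound 2 to compound 4 (within the scatter), so these two methyl patterns cannot be told apart at this position on a double-bonded chain carbon. No supporting data are available to explain the difference between the hydroxylated and dimethylated groups.

As far as these compounds go, it remains open whether a single methyl, a methoxy or an amine on this aromatic ring would stay with the dimethylphenyl compounds or with the hydroxylated ones. From the compounds shown here alone, it is also open whether a carboxylic acid or a longer chain here would fall outside both levels.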